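The source may hold more compounds than are shown below. What is called first, only, known or untested is meant among the compounds shown, and "the series" means these compounds.

Compound 1, `O[C@H]1CCc2ccccc2[C@@H]1n1ccnc1`: in an ADME assay on J774.A1 cells (Mus musculus) for cytotoxicity, read by MTT assay (on this read-out lower numbers stand for higher toxicity in this test and higher numbers for lower toxicity in this test), its value is a limit, > 100 ug/mL.
Compound 2, `O[C@H]1CCc2ccccc2[C@@H]1n1ccnn1`: in this assay compound 2 gives 35.6 ug/mL.
Compound 3, `O=[N+]([O-])c1ccc(O[C@H]2CCc3ccccc3[C@@H]2n2ccnc2)cc1`: in this assay compound 3 gives 21.4 ug/mL.

The change 1H-1,2,3-triazol-1-yl in place of 1H-imidazol-1-yl on a saturated ring carbon made an at least 2.8-fold lower number from compound 1 to compound 2 (0.44 log units; beyond the scatter); its true size is open because of the limit of > 100 ug/mL in this assay, at which 1 of the 3 values shown sits. How the core of compound 3 differs from that of compound 1 is not broken down here. Compound 4, `O=[N+]([O-])c1ccc(O[C@H]2CCc3ccccc3[C@@H]2n2ccnn2)cc1`, carries the same kind of change from compound 3, (1H-1,2,3-triazol-1-yl in place of 1H-imidazol-1-yl on a saturated ring carbon), though here the place is next to the ring atom that bears a large group rather than a hydroxy group. Compound 4 is expected to show a 1.8-fold lower number from compound 3 to compound 4 (0.25 log units; within the scatter), resting on an at least 2.8-fold lower number from compound 1 to compound 2 (0.44 log units; beyond the scatter) from compound 1 to compound 2, while the limit there leaves the size uncertain. Compound 4 is estimated at 12 ug/mL, within 5 ug/mL to 30 ug/mL.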

Compound 4, half-maximal cytotoxic concentration: > 100 ug/mL
Compound 4: a limit, no number; the forecaster's own chance of this, stated with the estimate: 5%; middle value at least 8.3-fold (0.92 log units) from the limit.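

In this assay, putting 1H-1,2,3-triazol-1-yl in place of 1H-imidazol-1-yl gave an at least 4.6-fold higher number from compound 3 to compound 4 (0.66 log units; beyond the scatter), so the change did not carry over from the core of compound 1 to the core of compound 3, and its direction reversed: the same change on two cores in this assay, an at least 2.8-fold lower number (0.44 log units; beyond the scatter) from compound 1 to compound 2 and an at least 4.6-fold higher number (0.66 log units; beyond the scatter) from compound 3 to compound 4, at least 13-fold (1.11 log units) apart, beyond the scatter of two such steps. As far as these compounds go, the exact size of each step remains unknown, as both rest on a limit: the limit of > 100 ug/mL in this assay, at which 2 of the 4 values shown sit. These two pairs show that the outcome of this change depends on the core, but they give no rule for predicting it on another core.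

From the compounds shown here alone, it remains open whether an ether bearing a methoxy group or an amine in place of the nitro group would behave like compound 3 and compound 4 or like compound 1 and compound 2. Going by these compounds, how a 1H-1,2,4-triazol-1-yl group would fare on either core also stays open.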